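Lengthening the Nitrogen-Bound Chain in the Writhing Test

The source may hold more compounds than are shown below. What is called first, only, known or untested is meant among the compounds shown, and "the series" means these compounds.

Compound 1 `Cc1cc(=O)oc2c1c(C)nn2C`: 11.6 mg/kg in a functional assay on the whole organism with Mus musculus as the target, in the writhing test; a lower number here means that less compound is needed, a higher number that more compound is needed for the effect
Compound 2 `CCn1nc(C)c2c(C)cc(=O)oc21`: 24.9 mg/kg in this assay
Compound 3 `Cc1cc(=O)oc2c1c(CC(=O)O)nn2C`: > 100 mg/kg in this assay, a limit of the assay rather than a number

Three compounds share one core and differ at two saturated chain carbons. Among the two numbers reported, compound 2 gives the higher one; the step of a 2.1-fold higher number from compound 1 to compound 2 (0.33 log units; beyond the scatter) is modest but beyond the scatter. The other measured step, an at least 8.6-fold higher number from compound 1 to compound 3 (0.93 log units; beyond the scatter), touches a different position and ends at a limit (the limit of > 100 mg/kg in this assay, at which 1 of the 3 values shown sits), so it says little about the chain bound to the aromatic nitrogen.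

Compound 4 `CCCCn1nc(C)c2c(C)cc(=O)oc21` differs from compound 2 by ethyl in place of hydrogen on a saturated chain carbon, two bonds along the chain from an aromatic nitrogen. For the measured compounds named here, the one step that bears on it is the one from compound 1 to compound 2, where a longer chain at the same nitrogen raised the number modestly. On that basis compound 4 is expected to give a somewhat higher number than compound 2, with a step of about a 1.8-fold higher number from compound 2 to compound 4 (0.26 log units; within the scatter), though the scatter leaves room for no change at all. Compound 4 is therefore estimated at 45 mg/kg, within a range of 20 mg/kg to 100 mg/kg.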

Compound 4, dose for half-maximal effect: > 100 mg/kg
Compound 4: only a limit was reported; the forecaster's own chance of this, stated with the estimate: 15%; middle value at least 2.2-fold (0.34 log units) from the limit.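

In this assay compound 4 gives > 100 mg/kg, which is a limit of the assay and not a number. Ethyl in place of hydrogen, two bonds along the chain from an aromatic nitrogen, brings an at least 4.0-fold higher number from compound 2 to compound 4 (0.60 log units; beyond the scatter), and the whole change from the methyl of the first compound to the butyl chain brings an at least 8.6-fold higher number from compound 1 to compound 4 (0.93 log units; beyond the scatter). Across the three chains on this nitrogen the number therefore rises each time, no compound shown goes against that, and the second rise exceeds the earlier 2.1-fold higher number from compound 1 to compound 2 (0.33 log units; beyond the scatter), although the size of both new steps stays open at the top: the limit of > 100 mg/kg in this assay, at which 2 of the 4 values shown sit.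

The compounds shown leave open how the number moves at the intermediate length, which a propyl chain on this nitrogen would show, and how far compound 4 lies past its limit. They also leave open whether a chain of this length ending in an amine or a hydroxy group would give a lower number in this assay than the plain butyl chain.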